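Furan-2-yl in place of phenyl: compound 3 to compound 4

A few compounds are considered here, and "the series" means these few. Any claim that something is new, unique, unknown or untested is made for them only; others in the source may bear on it.

Compound 3 `Cc1nc(N)c2c(-c3ccccc3)cn([C@@H]3O[C@H](CO)[C@@H](O)[C@H]3O)c2n1` gives in a functional assay on HCT-116 cells (Homo sapiens), read by MTT assay, with a stated time of 72 h (a higher number here means a weaker inhibitor, a lower number a stronger inhibitor), only a limit of the assay, > 100000 nM, not a number. Compound 2 `COc1nc(N)nc2c1c(-c1ccccc1)cn2[C@@H]1O[C@H](CO)[C@@H](O)[C@H]1O`, which also bears phenyl, gives in this assay a limit as well, > 20000 nM. Compound 1 `COc1ncnc2c1c(-c1ccoc1)cn2[C@@H]1O[C@H](CO)[C@@H](O)[C@H]1O`, with a different five-membered ring on a different core, gives 110 nM in this assay. Compound 4 `Cc1nc(N)c2c(-c3ccco3)cn([C@@H]3O[C@H](CO)[C@@H](O)[C@H]3O)c2n1` differs from compound 3 by furan-2-yl in place of phenyl on an aromatic carbon. No step between measured compounds is shown, so the size of this step rests on guesswork; a move toward stronger inhibition is expected, of uncertain size, and compound 3 stands only at the limit of > 100000 nM in this assay, at which 1 of the 3 values shown sits. Compound 4 is estimated at 30000 nM, within 3000 nM to 150000 nM, so the expected step is an at least 3.3-fold lower number from compound 3 to compound 4 (0.52 log units; beyond the scatter).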

Compound 4, half-maximal inhibitory concentration: > 20000 nM
Compound 4 ended at the assay's limit (the forecaster's own chance of this, stated with the estimate: 50%); the middle value lies beyond the limit too.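

Compound 3 gives only a limit in this assay, > 100000 nM. For the compounds shown here, compound 4 also gives only a limit, > 20000 nM, and no step between compound 3 and compound 4 can be read. On these data alone, whether furan-2-yl in place of phenyl changes inhibition at all stays open.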